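The source may report more compounds than this note shows. Statements on the series, on what has been measured and on what is new or still open speak of the compounds shown alone.

In an ADME assay on MT4 cells (Homo sapiens) for cytotoxicity, read by MTT assay (a lower number here means that less compound is tolerated, a higher number that more compound is tolerated), compound 1 `O=C1c2ccccc2C(=O)N1CCOC(=S)N(C(=O)c1c(F)cccc1F)c1ccc(Cl)cc1` gives 39000 nM and compound 2 `O=C1c2ccccc2C(=O)N1CCOC(=S)N(C(=O)c1cccc(Cl)c1Cl)c1ccc(Cl)cc1` gives 54000 nM. Among the measured compounds shown here, these are the only two numbers so far, and compound 2 cannot be separated from compound 1: the one measured step, a 1.4-fold higher number from compound 1 to compound 2 (0.14 log units; within the scatter), stays within the scatter. Compound 3 `O=C1c2ccccc2C(=O)N1CCOC(=S)N(C(=O)c1ccc(Cl)c(Cl)c1)c1ccc(Cl)cc1`, not yet measured, has 3,4-dichlorophenyl in place of 2,3-dichlorophenyl on a carbonyl carbon. For the measured compounds named here, the one measured step bears on this change, as it also exchanged the aryl group on a carbonyl carbon. On that single precedent, no step beyond the scatter is expected in this assay, and no direction can be assigned with confidence. The expected change is a 1.2-fold lower number from compound 2 to compound 3 (0.08 log units; within the scatter). For compound 3 the estimated value is 45000 nM, with an expected range of 20000 nM to 95000 nM.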

Compound 3, half-maximal cytotoxic concentration: 35000 nM
Estimate against measurement, compound 3: 1.3-fold (0.11 log units) above; the measured number falls inside the stated range.
By their numbers in this assay, from the lowest: compounds 3, 1 and 2 (each within the scatter of the next).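

In this assay, the same atoms rearranged as 3,4-dichlorophenyl in place of 2,3-dichlorophenyl on a carbonyl carbon give a 1.5-fold lower number from compound 2 to compound 3 (0.19 log units; within the scatter) and so show no effect that can be separated from the scatter. Exchanging 2,6-difluorophenyl for 3,4-dichlorophenyl gives a 1.1-fold lower number from compound 1 to compound 3 (0.05 log units; within the scatter) and likewise stays within it, so the three aryl groups at this position cannot be told apart in this assay. No supporting measurement is available to explain this result.

As far as these compounds go, it remains open whether a group of another kind on this carbonyl carbon, such as an amine, a phenyl bearing a carboxylic acid or a longer alkyl chain, would produce a step beyond the scatter. From the compounds shown here alone, the rest of the core is the same in all three compounds, so changes elsewhere also remain untested here.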